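Chlorophenyl in Place of Cyclohexylcarbonyl: Expected Cytotoxicity

The source may hold more compounds than are shown below. What is called first, only, known or untested is meant among the compounds shown, and "the series" means these compounds.

Compound 3 `NCCNc1cc(N2CCN(C(=O)C3CCCCC3)CC2)nc2ccccc12` sits at the ceiling of an ADME assay on HEp-2 cells (Homo sapiens) for cytotoxicity, read by CCK-8 assay, with a stated time of 6 days; on this read-out higher numbers stand for lower toxicity in this test and lower numbers for higher toxicity in this test. In this assay compound 3 gives > 100000 nM, which is a limit of the assay rather than a number. Compound 2 `CS(=O)(=O)N1CCN(c2cc(NCCN)c3ccccc3n2)CC1` likewise returns only a limit, giving > 100000 nM in this assay. For the measured compounds named here, compound 1 `NCCNc1cc(N2CCN(c3cccc(Cl)c3)CC2)nc2ccccc12` is the one compound with a measured number, giving 6400 nM in this assay. Going by the values given here, compound 3 therefore stands at the limit of > 100000 nM in this assay, at which 2 of the 3 values shown sit, alongside compound 2, with compound 1 the only value beneath that ceiling.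

Compound 4 `NCCNc1cc(N2CCN(c3ccc(Cl)cc3)CC2)nc2ccccc12` differs from compound 3 in one place: 4-chlorophenyl in place of cyclohexylcarbonyl on an amine nitrogen in a ring. The measured steps that bear on this are an at least 15-fold higher number from compound 1 to compound 3 (1.19 log units; beyond the scatter) and, for comparison, an at least 15-fold higher number from compound 1 to compound 2 (1.19 log units; beyond the scatter), whereas a step that the two limits leave unreadable from compound 2 to compound 3 yields no size. Because the change in compound 4 reverses the replacement seen in an at least 15-fold higher number from compound 1 to compound 3 (1.19 log units; beyond the scatter), with a 4-chlorophenyl rather than a 3-chlorophenyl entering, the author expects a large downward step, toward higher toxicity, of about an at least 14-fold lower number from compound 3 to compound 4 (1.15 log units; beyond the scatter). Compound 4 is accordingly estimated at 7000 nM, with an expected range from 2000 nM to 30000 nM.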

Compound 4, half-maximal cytotoxic concentration: 6600 nM
Estimate against measurement, compound 4: 1.1-fold (0.03 log units) above; the range from low to high includes it.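

With 4-chlorophenyl on the same amine nitrogen in the ring, the position of the chlorine on the phenyl ring makes no difference that can be read in this assay: the comparison gives a 1.0-fold higher number from compound 1 to compound 4 (0.01 log units; within the scatter), which lies within the scatter. The other two steps, an at least 15-fold lower number from compound 3 to compound 4 (1.18 log units; beyond the scatter) and an at least 15-fold lower number from compound 2 to compound 4 (1.18 log units; beyond the scatter), show that the large difference from the cyclohexylcarbonyl and methylsulfonyl compounds is not confined to 3-chlorophenyl, but holds for both chlorophenyl groups shown. Compound 2 and compound 3 remain at a limit of the assay, not at a number: the limit of > 100000 nM in this assay, at which 2 of the 4 values shown sit.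

The step between compound 2 and compound 3 cannot be read, so these two groups cannot be ranked against each other. The compounds shown also leave open whether a plain phenyl, a benzyl group or a methoxyphenyl on that nitrogen would fall with the chlorophenyl compounds or at the limit.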